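Indolylmethyl in place of oxanylmethyl: expected shift in lipophilicity

The source may report more compounds than this note shows. Statements on the series, on what has been measured and on what is new or still open speak of the compounds shown alone.

Working notes on the series. Compound 1 `CNC(=O)c1cc(C(=O)NC2CCC2)cn(Cc2ccncc2)c1=O` and compound 2 `CNC(=O)c1cc(C(=O)NC2CC2)cn(CC2CCCOC2)c1=O` share the same core and have both been measured in a physicochemical assay for lipophilicity, at pH 7.4; a lower number here means a more polar compound, a higher number a more lipophilic compound. In this assay compound 1 gives 1.7. In this assay compound 2 gives 2, the higher of the two numbers, but the gap to compound 1 lies within the usual scatter, so no order between compound 1 and compound 2 can be read from these two values.

Compound 3 `CNC(=O)c1cc(C(=O)NC2CC2)cn(Cc2cccc3cc[nH]c23)c1=O` has not yet been measured in this assay. It differs from compound 2 in one place: 1H-indol-7-yl in place of oxan-3-yl on a saturated chain carbon bound to an aromatic nitrogen. A six-membered non-aromatic ring with one hetero atom leaves, and a five-membered aromatic ring with one hetero atom joined to a six-membered aromatic ring of carbon only enters, on a saturated chain carbon bound to an aromatic nitrogen.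

Among the compounds with values here, no measured pair in the set isolates this change, so the size of the step rests on the structural difference alone. The step of a number 1.00 log units higher from compound 2 to compound 3 (beyond the scatter) is expected to be upward and clearly beyond the scatter. For compound 3 the estimated value in this assay is 3, with a range from 2.5 to 3.5.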

Compound 3, distribution coefficient: 3.7
Compound 3: the middle estimate sits 0.70 log units below what was measured; measured number above the stated range.
By their numbers in this assay, from the lowest: compounds 1 and 2 (each within the scatter of the next); then compound 3.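

In this assay, 1H-indol-7-yl in place of oxan-3-yl on a saturated chain carbon bound to an aromatic nitrogen gives a number 1.70 log units higher from compound 2 to compound 3 (beyond the scatter), a large step and the only one in the series that can be read from a change in one place. Compound 1 and compound 2 differ in more than one place, so they said nothing about this position alone; the new step shows that the number in this assay can respond strongly to the group held there. The step replaces one six-membered non-aromatic ring with a five-membered and a six-membered aromatic ring and brings in a hydrogen-bond donor, but no measurement available here explains why the number moves this far.

This single step cannot separate the contributions of the added heavy atoms, the aromatic rings and the hydrogen-bond donor of 1H-indol-7-yl. Also open, on these data alone, is how the number would respond to a carboxylic acid or an amine on a saturated chain carbon bound to an aromatic nitrogen, including whether it would fall from the level of compound 2.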